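Methoxycarbonyl to (2-ureidoethyl)carbamoyl: working notes

The compounds below may be only part of what the source reports. "The series", "measured", "known", "first", "only" and "open" are said of these compounds alone.

Measured so far in a functional assay on 1321N1 cells for antagonist activity at P2Y purinoceptor 6 (Homo sapiens), read by fluorescence and calcium flux; on this read-out lower numbers stand for stronger inhibition and higher numbers for weaker inhibition:
- compound 1, `O=C(O)C1=Cc2cc(I)ccc2OC1C(F)(F)F`, reports only a limit of the assay: > 100000 nM.
- compound 2, `O=[N+]([O-])C1=Cc2ccccc2OC1C(F)(F)F`, gives 2910 nM.
- compound 3, `COC(=O)c1ccc(C#Cc2ccc3c(c2)C=C([N+](=O)[O-])C(C(F)(F)F)O3)cc1`, gives 7130 nM.

The value of compound 1 is a limit and not a number; it sits at the limit of > 100000 nM in this assay, at which 1 of the 3 values shown sits. Of the two numbers in this assay, compound 3 stands highest, and the nearest number, that of compound 2, is lower by a gap beyond the usual scatter. Going by the values given here, compound 2 and compound 3 differ in more than one place, so no single step between them is measured.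

Compound 4, `NC(=O)NCCNC(=O)c1ccc(C#Cc2ccc3c(c2)C=C([N+](=O)[O-])C(C(F)(F)F)O3)cc1`, is the next compound for this assay. It differs from compound 3 by (2-ureidoethyl)amino in place of methoxy on a carbonyl carbon. Read one bond further out, methoxycarbonyl becomes (2-ureidoethyl)carbamoyl, while the rest of compound 3 is kept.

No measured pair among compounds 1 to 3 carries this change, so its effect in this assay is not known from the numbers shown. The expectation is a step from compound 3 to compound 4 of a 1.4-fold lower number from compound 3 to compound 4 (0.15 log units; within the scatter), that is, no move beyond the scatter in either direction. On that basis compound 4 is estimated at 5000 nM in this assay, with a range from 1500 nM to 20000 nM.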

Compound 4, half-maximal inhibitory concentration: 10600 nM
Compound 4: middle estimate off by 2.1-fold (0.33 log units), on the low side; the range from low to high includes it.
By their numbers in this assay, from the lowest: compound 2; then compounds 3 and 4 (each within the scatter of the next). At a limit, above all of these: compound 1.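

In this assay, going by these compounds alone, (2-ureidoethyl)amino in place of methoxy on a carbonyl carbon gives the first single-place step (a 1.5-fold higher number from compound 3 to compound 4 (0.17 log units; within the scatter)), so the two groups cannot be told apart at this position. This holds although the entering group is much the larger of the two and brings hydrogen-bond donors where methoxy has none, which means that on this pair neither the added bulk nor the added donors move the read-out beyond the scatter, and the carbonyl carbon can carry a far longer substituent without a measurable change. Within the data shown here, nothing measured on these compounds explains why the read-out holds, and the only value on record that is not a number, the limit of compound 1, has no bearing on this pair.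

Going by these compounds, whether an amine, a carboxylic acid or a longer chain in place of (2-ureidoethyl)amino on this carbonyl carbon would read any differently stays open, since one pair gives a single step at this position. Compound 2 differs from compound 3 and compound 4 in more than one place, and compound 1 likewise, so the steps linking them cannot be read.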